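The source may hold more compounds than are shown below. What is called first, only, known or untested is meant among the compounds shown, and "the series" means these compounds.

Measured so far:
- compound 1 `NS(=O)(=O)c1ccc(Nc2nc(N/N=C/c3ccc(C(F)(F)F)cc3)nc(Nc3ccccc3)n2)cc1`: 46400 nM
- compound 2 `Cc1nn(-c2ccccc2)cc1/C=N/Nc1nc(Nc2ccccc2)nc(Nc2ccc(S(N)(=O)=O)cc2)n1`: 7010 nM

Both compounds share one core and differ only in the group that hangs from a carbon with a double bond to nitrogen. In a functional assay on HCC 2998 cells (Homo sapiens) for inhibition, read by sulforhodamine B assay, with a stated time of 48 h (a lower number here means that less compound is tolerated, a higher number that more compound is tolerated), compound 1 gives 46400 nM, and compound 2 gives 7010 nM. For the measured compounds named here, the one step between them, a 6.6-fold lower number from compound 1 to compound 2 (0.82 log units; beyond the scatter), shows that exchanging the aryl group at this position can move the number by a modest but real amount. Going by the values given here, compound 2 thus stands with the lowest number of the two measured, and compound 1 is its only neighbour.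

Compound 3 `NS(=O)(=O)c1ccc(Nc2nc(N/N=C/c3ccccn3)nc(Nc3ccccc3)n2)cc1` has not yet been measured. It differs from compound 2 by pyridin-2-yl in place of 3-methyl-1-phenyl-1H-pyrazol-4-yl on a carbon with a double bond to nitrogen. Among the compounds with values here, no measured step covers this exact exchange; the only guide is that the step from compound 1 to compound 2 changed the number by a modest amount when the aryl group here was swapped. A change of similar size, in either direction, is therefore plausible, with a somewhat higher number for compound 3 than for compound 2 expected as the central estimate, because compound 2 holds the lowest number seen so far at 7010 nM. The expected step is a 2.1-fold higher number from compound 2 to compound 3 (0.33 log units; beyond the scatter). Compound 3 is estimated at 15000 nM, within a range from 4000 nM to 60000 nM in this assay.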

Compound 3, concentration lethal to 50% of the cells: > 100000 nM
Compound 3: no number, only a limit (the forecaster's own chance of this, stated with the estimate: 10%); middle value at least 6.6-fold (0.82 log units) away from the limit.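

Compound 3 carries no number, only a limit of the assay: the limit of > 100000 nM in this assay, at which 1 of the 3 values shown sits. Replacing the two-ring 3-methyl-1-phenyl-1H-pyrazol-4-yl with the single-ring pyridin-2-yl gives an at least 14-fold higher number from compound 2 to compound 3 (1.15 log units; beyond the scatter), which shows that the group on this carbon with a double bond to nitrogen can shift the reading in this assay much further than the earlier step, a 6.6-fold lower number from compound 1 to compound 2 (0.82 log units; beyond the scatter), had revealed. Pyridin-2-yl also compares unfavourably with the single-ring 4-(trifluoromethyl)phenyl, with an at least 2.1-fold higher number from compound 1 to compound 3 (0.33 log units; beyond the scatter), so among these three compounds the pyrazole-bearing compound 2 has the lowest reading and compound 3 the highest, with every step beyond the scatter.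

As far as these compounds go, these three compounds cannot separate the effect of the ring nitrogen in pyridin-2-yl from that of the overall change in group, and the position of compound 3 beyond the limit also remains unknown. A plain phenyl, a pyridin-3-yl or a 4-aminophenyl group at this place would be needed to tell how far the reading follows the ring nitrogen, the ring count or the substituent.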